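The source may hold more compounds than are shown below. What is called first, only, known or untested is meant among the compounds shown, and "the series" means these compounds.

Compound 1, `CCCN(CCC)c1cc(C)nc2c(-c3ncc(C(F)(F)F)cc3Cl)c(C)nn12`, in an assay on isolated protein for binding affinity to corticotropin-releasing factor receptor 1 (Homo sapiens) (on this read-out higher numbers stand for weaker inhibition and lower numbers for stronger inhibition), gives 1.2 nM.
Compound 2, `CCCCN(CCC)c1cc(C)nc2c(-c3ncc(C(F)(F)F)cc3Cl)c(C)nn12`, in this assay gives 1.2 nM.

Compound 2 thus stands level with compound 1 at the digits shown. Compound 3, `CCCN(Cc1ccccc1)c1cc(C)nc2c(-c3ncc(C(F)(F)F)cc3Cl)c(C)nn12`, differs from compound 2 by phenyl in place of propyl on a saturated chain carbon bound to a nitrogen on an aromatic ring. Within the data shown here, the only measured step, no change at the digits printed from compound 1 to compound 2 (within the scatter), added a methyl further out on the chain and left the number unchanged within the scatter; no measured step brings a ring into this position. The step from compound 2 to compound 3 is therefore expected to be small, estimated as a 1.7-fold higher number from compound 2 to compound 3 (0.22 log units; within the scatter). Compound 3 is expected near 2 nM, between 0.5 nM and 8 nM.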

Compound 3, inhibition constant: 1.7 nM
For compound 3 the middle estimate is 1.2-fold (0.07 log units) above the measured one, and the stated range covers the measured number.
By their numbers in this assay, from the lowest: compounds 1, 2 and 3 (each within the scatter of the next).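

Until now this place held only saturated chains, and a ring is new here. In this assay, phenyl in place of propyl on a saturated chain carbon bound to a nitrogen on an aromatic ring gives a 1.4-fold higher number from compound 2 to compound 3 (0.15 log units; within the scatter), and phenyl in place of ethyl gives a 1.4-fold higher number from compound 1 to compound 3 (0.15 log units; within the scatter). So butyl and benzyl cannot be told apart on this read-out, and no measurement shown offers an explanation.

As far as these compounds go, whether this holds for a benzyl ring carrying a carboxylic acid or an amine stays open. So does the outcome with a pyridine ring or a longer chain ending in phenyl.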